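The compounds below may be only part of what the source reports. "The series", "measured", "known", "first", "only" and "open" are said of these compounds alone.

Series notes on three chalcone-type anilines and a fourth analogue.

Compound 1 `C=C(Br)C(=O)Nc1ccc(C(=O)/C=C/c2ccc(OC)c(OC)c2)cc1` gives 1300 nM in a functional assay on L1210 cells (Mus musculus) for antiproliferative activity, with a stated time of 48 h; a higher number here means a weaker inhibitor, a lower number a stronger inhibitor. Compound 2 `C=C(Br)C(=O)Nc1ccc(C(=O)/C=C/c2ccc(OC)c(OC)c2OC)cc1` is the same skeleton carrying one more methoxy group; in this assay compound 2 gives 630 nM. The change between them is methoxy in place of hydrogen on an aromatic carbon and the step recorded is a 2.1-fold lower number from compound 1 to compound 2 (0.31 log units; beyond the scatter).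

Compound 3 `COc1cc(/C=C/C(=O)c2ccc(N)cc2)cc(OC)c1` carries the free aniline in place of the bromoacrylamide and a different methoxy pattern on the far ring; in this assay compound 3 gives 6000 nM, the highest number of the three. The difference between the core of compound 1 and the core of compound 3 is not broken down here.

Compound 4 `COc1cc(/C=C/C(=O)c2ccc(N)cc2)cc(OC)c1OC` stands to compound 3 as compound 2 stands to compound 1: methoxy in place of hydrogen on an aromatic carbon. The surroundings of the entering group are not identical in the two pairs. In the pair of compound 1 and compound 2 the place is ortho to a large group, ortho to a methoxy group and meta to a methoxy group; in the pair of compound 3 and compound 4 it is ortho to two methoxy groups and para to a large group. It is therefore the same kind of change, not the same change.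

Among the measured compounds shown here, the expectation for compound 4 in this assay rests on the single measured instance, the step from compound 1 to compound 2 of a 2.1-fold lower number from compound 1 to compound 2 (0.31 log units; beyond the scatter), transferred to the value of compound 3 at 6000 nM. Compound 4 is expected to give a step of a 2.1-fold lower number from compound 3 to compound 4 (0.33 log units; beyond the scatter) in this assay. For the measured compounds named here, the estimate for compound 4 is 2800 nM, with an expected range from 1200 nM to 6500 nM, the width reflecting that only one prior instance of this kind of change, on a different core, is available.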

Compound 4, half-maximal inhibitory concentration: 7800 nM
Beside the measured number, compound 4's estimate is 2.8-fold (0.44 log units) below it; the measured number lies above the stated range.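

On the free aniline core in this assay, methoxy in place of hydrogen on an aromatic carbon gives a 1.3-fold higher number from compound 3 to compound 4 (0.11 log units; within the scatter), so the lower number seen on the bromoacrylamide core does not recur on this core. The same kind of change therefore does not carry over with the same size from one core to the other, and the two steps differ: the same change on two cores in this assay, a 2.1-fold lower number (0.31 log units; beyond the scatter) from compound 1 to compound 2 and a 1.3-fold higher number (0.11 log units; within the scatter) from compound 3 to compound 4, 2.7-fold (0.43 log units) apart, beyond the scatter of two such steps

This does not show what sets the two steps apart, since each core supplies a single pair and the entering methoxy stands in a different place in each, ortho to two methoxy groups and para to a large group in the aniline pair, so that core and place cannot be separated, and no rule for the series follows from two steps.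

The compounds shown leave open whether the step would follow the core or the place if the same methoxy pattern stood on both the free aniline and the bromoacrylamide cores. They also leave open how a hydroxy group or an ethoxy group at that same place would compare with methoxy on either core.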